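The source may report more compounds than this note shows. Statements on the series, on what has been measured and on what is new or still open speak of the compounds shown alone.

Measured in a functional assay on EBC-1 cells (Homo sapiens) for antiproliferative activity, read by sulforhodamine B assay, with a stated time of 72 h; on this read-out higher numbers stand for weaker inhibition and lower numbers for stronger inhibition:

- compound 1 `Cn1cc(-c2ccc(=O)n(CCOc3ccnc4cc(OCCCCC(=O)NO)ccc34)n2)cn1`: 370 nM
- compound 2 `Cn1cc(-c2ccc(=O)n(CCOc3ccnc4cc(OCCCCCCC(=O)NO)ccc34)n2)cn1`: 210 nM
- compound 3 `Cn1cc(-c2ccc(=O)n(CCOc3ccnc4cc(OCCCCCC(=O)Nc5ccccc5N)ccc34)n2)cn1`: 370 nM

Compound 3 reads the same as compound 1, and the gap to compound 2 lies within the scatter. Compound 4 `Cn1cc(-c2ccc(=O)n(CCOc3ccnc4cc(OCCCCCS)ccc34)n2)cn1` differs from compound 3 as follows: sulfanyl in place of (2-aminophenyl)carbamoyl on a saturated chain carbon, five bonds along the chain from an oxygen on an aromatic ring. The end of the chain thus loses its anilide-type group, (2-aminophenyl)carbamoyl, and carries sulfanyl instead.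

For the measured compounds named here, three measured steps bear on this only indirectly, since each alters the group at the chain end. They are no change at the digits printed from compound 1 to compound 3 (within the scatter), a 1.8-fold higher number from compound 2 to compound 3 (0.25 log units; within the scatter) and a 1.8-fold lower number from compound 1 to compound 2 (0.25 log units; within the scatter), and all stay within the scatter. Going by the values given here, none of the measured compounds carries sulfanyl, so the data do not show how that group behaves in this assay. A step beyond the scatter is therefore not expected, although the uncertainty is wide, mostly towards higher numbers. The expected step is a 1.5-fold higher number from compound 3 to compound 4 (0.17 log units; within the scatter). Compound 4 is estimated at 550 nM, with an expected range of 180 nM to 1800 nM.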

Compound 4, half-maximal inhibitory concentration: 640 nM
For compound 4 the middle estimate is 1.2-fold (0.07 log units) below the measured one, and the stated range covers the measured number.
By their numbers in this assay, from the lowest: compounds 2, 1, 3 and 4 (each within the scatter of the next, the first and the last beyond it).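

In this assay, for the compounds shown here, replacing the (2-aminophenyl)carbamoyl group with a single sulfur-bearing group at the end of the chain gives a 1.7-fold higher number from compound 3 to compound 4 (0.24 log units; within the scatter), and the matching comparison with the shorter hydroxamic acid gives a 1.7-fold higher number from compound 1 to compound 4 (0.24 log units; within the scatter), so sulfanyl, the first chain-end group here without a carbonyl, stays within the scatter of both. Going by these compounds alone, only the comparison with the longest hydroxamic acid chain, a 3.0-fold higher number from compound 2 to compound 4 (0.48 log units; beyond the scatter), gives a modest step beyond the scatter, the first such step. Nothing measured here accounts for these steps. The compounds shown leave open how a carboxylic acid or a primary amine would read at the same chain end. They also leave open whether a longer chain carrying sulfanyl would narrow the gap to compound 2.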